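Benzofuran in Place of Furan on an Inactive Nucleoside Core

The compounds below may be only part of what the source reports. "The series", "measured", "known", "first", "only" and "open" are said of these compounds alone.

Compound 1, `O=c1[nH]cnc2c1c(-c1ccoc1)cn2[C@@H]1O[C@H](CO)[C@@H](O)[C@H]1O`, gives > 20000 nM in a functional assay on A549 cells (Homo sapiens), read by MTT assay, with a stated time of 72 h; on this read-out higher numbers stand for weaker inhibition and lower numbers for stronger inhibition; this is a limit of the assay.
Compound 2, `COc1nc(N)nc2c1c(-c1ccsc1)cn2[C@@H]1O[C@H](CO)[C@@H](O)[C@H]1O`, gives > 100000 nM in this assay, again a limit.
Compound 3, `Nc1nc2c(c(-c3ccoc3)cn2[C@@H]2O[C@H](CO)[C@@H](O)[C@H]2O)c(=O)[nH]1`, gives > 20000 nM in this assay, also a limit.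

Compound 1 therefore stands only at a limit, and the two other values shown are limits as well. Among the compounds with values here, the one single-place step, a step that the two limits leave unreadable from compound 1 to compound 3, cannot be read because both of its ends sit at the limit of > 20000 nM in this assay, at which 2 of the 3 values shown sit. Compound 4, `O=c1[nH]cnc2c1c(-c1cc3ccccc3o1)cn2[C@@H]1O[C@H](CO)[C@@H](O)[C@H]1O`, differs from compound 1 by 1-benzofuran-2-yl in place of furan-3-yl on an aromatic carbon. Within the data shown here, no measured step bears on this change, so no direction beyond the scatter can be drawn. Compound 4 is expected to give 30000 nM, within 5000 nM to 100000 nM, in this assay. This estimate means an expected step that the limit leaves unreadable from compound 1 to compound 4.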

Compound 4, half-maximal inhibitory concentration: > 20000 nM
Compound 4: no number, only a limit; the forecaster's own chance of this, stated with the estimate: 65%; the middle value does not contradict the limit.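

In this assay compound 4 gives > 20000 nM as a limit of the assay. Compound 1 and compound 4 sit at the same limit, so the step between them cannot be read: the limit of > 20000 nM in this assay, at which 3 of the 4 values shown sit.

On these data alone, how strongly any of the four compounds inhibits in this assay stays open, as does the effect of 1-benzofuran-2-yl in place of furan-3-yl.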